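The source may report more compounds than this note shows. Statements on the series, on what has been measured and on what is new or still open speak of the compounds shown alone.

Measured so far:
- compound 1 `NC(=O)[C@@H](CCC(F)(F)F)N(C[C@H]1CCCCO1)S(=O)(=O)c1ccc(Cl)cc1` — > 300 mL/min/kg in an in vitro ADME assay on microsomes from liver (Homo sapiens) for metabolic stability, read by HPLC; on this read-out higher numbers stand for fast clearance and lower numbers for slow clearance
- compound 2 `NC(=O)[C@@H](CCC(F)(F)F)N(C[C@@H]1COCCO1)S(=O)(=O)c1ccc(Cl)cc1` — 117 mL/min/kg in this assay

Compound 1 sits at the limit of this assay (the limit of > 300 mL/min/kg in this assay, at which 1 of the 2 values shown sits), so only a bound is known for it. For the measured compounds named here, the one measured step, an at least 2.5-fold lower number from compound 1 to compound 2 (0.40 log units; beyond the scatter), exchanged the same ring at the same place and lowered the number.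

Compound 3 `NC(=O)[C@@H](CCC(F)(F)F)N(C[C@H]1CCO1)S(=O)(=O)c1ccc(Cl)cc1` differs from compound 1 by oxetan-2-yl in place of oxan-2-yl on a saturated chain carbon bound to a sulfonamide nitrogen. The step to compound 2 is the only one that bears on this change; by analogy a drop from the limit is expected, an at least 2.0-fold lower number from compound 1 to compound 3 (0.30 log units; that floor lies within the scatter), with the chance that compound 3 again reads only as a limit.

Estimated for compound 3 in this assay: 150 mL/min/kg, range 60 mL/min/kg to 320 mL/min/kg.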

Compound 3, clearance: 63.8 mL/min/kg
For compound 3 the middle estimate is 2.4-fold (0.37 log units) above the measured one; low and high end bracket the measured number.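

Oxetan-2-yl in place of oxan-2-yl gives an at least 4.7-fold lower number from compound 1 to compound 3 (0.67 log units; beyond the scatter) in this assay, so 1,4-dioxan-2-yl is not the only ring at this place that brings the number down from compound 1. Compound 1 is a limit, so this step has only a floor: the limit of > 300 mL/min/kg in this assay, at which 1 of the 3 values shown sits. The two replacement rings are not separated, with a 1.8-fold lower number from compound 2 to compound 3 (0.26 log units; within the scatter).

Still open, on these data alone, is whether any ring is needed on this saturated chain carbon, or whether an open-chain ether or an amine there gives a similar read-out.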